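This account rests on a few compounds, and the source may have more. Where it says the series, first, only, none or still open, it means among the compounds named here.

Measured compounds:
Compound 1 `CN1CCN(CCCOc2cccc3nc(Nc4ccc(Cl)c(F)c4)ccc23)CC1` gives 13200 nM in a functional assay on cells (Panel breast (Carcinoma cell lines), Homo sapiens) for inhibition, read by sulforhodamine B assay, with a stated time of 48 h; a higher number here means that more compound is tolerated, a lower number that less compound is tolerated.
Compound 2 `CN1CCN(CCCOc2cccc3nc(Nc4ccc(F)c(F)c4)ccc23)CC1` gives 20300 nM in this assay.

Among these two numbers compound 2 sits at the higher end, but the gap to compound 1 is small: the step of a 1.5-fold higher number from compound 1 to compound 2 (0.19 log units; within the scatter) lies within the scatter, so the two compounds cannot be ordered against each other. Compound 3 `CN1CCN(CCCOc2cccc3nc(Nc4cc(Cl)cc(Cl)c4)ccc23)CC1` has not yet been measured. It differs from compound 2 by 3,5-dichlorophenyl in place of 3,4-difluorophenyl on a nitrogen on an aromatic ring. Among the compounds with values here, only one measured step bears on this change, the exchange of one halogen for another on the same ring, a 1.5-fold higher number from compound 1 to compound 2 (0.19 log units; within the scatter), and that step stayed within the scatter. Within the data shown here, compound 3 carries two chlorines where compound 2 carries two fluorines, a change that has no direct measured counterpart here. The step of a 1.6-fold lower number from compound 2 to compound 3 (0.19 log units; within the scatter) is therefore expected to be small, with no direction beyond the scatter. Compound 3 is estimated at 13000 nM, between 4500 nM and 38000 nM.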

Compound 3, concentration lethal to 50% of the cells: 21800 nM
Compound 3: the middle estimate sits 1.7-fold (0.22 log units) below what was measured; the measured number falls inside the stated range.
By their numbers in this assay, from the lowest: compounds 1, 2 and 3 (each within the scatter of the next).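

Within the data shown here, the step from 3,4-difluorophenyl to 3,5-dichlorophenyl on this nitrogen replaces both halogens and alters the substitution pattern, a larger change than the single halogen exchange seen earlier. Yet in this assay it reads a 1.1-fold higher number from compound 2 to compound 3 (0.03 log units; within the scatter), and the comparison with the chloro-fluoro compound reads a 1.7-fold higher number from compound 1 to compound 3 (0.22 log units; within the scatter), so all three halogenated phenyl groups lie within the scatter of one another. Nothing available explains why these numbers stay so close.

On these data alone, all three compounds carry only chlorine or fluorine on this phenyl ring, so it remains open whether a methoxy group, a nitrile or a carboxylic acid there would move the number beyond the scatter. The same question stands at the far end of the chain, where a morpholine could take the place of the methylpiperazine.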